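From 2-methylphenyl to 5-bromothiophen-2-yl on the sulfonyl sulfur

The compounds below may be only part of what the source reports. "The series", "measured", "known", "first", "only" and "open" are said of these compounds alone.

Compound 1 `Cc1ccccc1S(=O)(=O)N1C(=O)COC12C=CC(=O)C=C2` gives > 10000 nM in a functional assay on A549 cells (Homo sapiens) for inhibition, read by sulforhodamine B assay, with a stated time of 74 h (a higher number here means a weaker inhibitor, a lower number a stronger inhibitor), as a limit and not a number. Compound 2 `O=C1C=CC2(C=C1)OCC(=O)N2S(=O)(=O)c1ccccc1OC(F)(F)F` likewise gives > 10000 nM as a limit. Compound 3 `O=C1C=CC2(C=C1)OCC(=O)N2S(=O)(=O)c1ccccc1C(F)(F)F` also gives > 10000 nM as a limit. Compound 1 therefore stands at the limit of > 10000 nM in this assay, at which 3 of the 3 values shown sit, and offers no number to start from. Compound 4 `O=C1C=CC2(C=C1)OCC(=O)N2S(=O)(=O)c1ccc(Br)s1` brings 5-bromothiophen-2-yl in place of 2-methylphenyl on a sulfonyl sulfur in one change: 5-bromothiophen-2-yl in place of 2-methylphenyl on a sulfonyl sulfur. The nearest measured steps are a step that the two limits leave unreadable from compound 1 to compound 2 and a step that the two limits leave unreadable from compound 1 to compound 3 and a step that the two limits leave unreadable from compound 2 to compound 3 and each only swaps a group on an aromatic carbon. None gives a size to carry over, so only a loose expectation remains of a move toward a stronger inhibitor in this assay from that limit. The expected step is an at least 3.3-fold lower number from compound 1 to compound 4 (0.52 log units; beyond the scatter) and it may stay unreadable. Compound 4 is estimated at 3000 nM within an expected range from 300 nM to 15000 nM and may itself return only a limit.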

Compound 4, half-maximal inhibitory concentration: 50 nM
The estimate for compound 4 lay 60-fold (1.78 log units) above the measured number; the measured number lies below the stated range.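

In this assay, the group on the sulfonyl sulfur proved able to move the series off its limit: 5-bromothiophen-2-yl in place of 2-methylphenyl gives an at least 200-fold lower number from compound 1 to compound 4 (2.30 log units; beyond the scatter). The steps among compounds 1, 2 and 3, which only swap a group on an aromatic carbon, cannot be read. Compound 4 alone yields a number rather than a limit: the limit of > 10000 nM in this assay, at which 3 of the 4 values shown sit.

As far as these compounds go, the change replaces the ring and introduces bromine together, so the share of each remains open. How thiophen-2-yl without bromine, or 4-bromophenyl, would read on the same sulfur is also unresolved.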